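This account rests on a few compounds, and the source may have more. Where it says the series, first, only, none or still open, it means among the compounds named here.

Working notes on the series. The shared core of compound 1 `c1ccc(COc2ccccc2Nc2ncnc3cc4c(cc23)OCCOCCO4)cc1` is tested in a functional assay on DU-145 cells (Homo sapiens) for antiproliferative activity, read by MTT assay, with a stated time of 72 h; on this read-out lower numbers stand for stronger inhibition and higher numbers for weaker inhibition. In this assay compound 1 reaches only the assay limit of > 100000 nM. Compound 2 `c1ccc(COc2ccccc2Nc2ncnc3cc4c(cc23)OCCOCCOCCOCCO4)cc1` likewise gives only the limit of > 100000 nM in this assay. Within the data shown here, compound 3 `FC(F)(F)c1ccc(COc2cccc(Nc3ncnc4cc5c(cc34)OCCOCCOCCOCCO5)c2)cc1` is the one member with a measured number, 26900 nM in this assay. Compound 1 and compound 2 both sit at the limit (the limit of > 100000 nM in this assay, at which 2 of the 3 values shown sit). Compound 4 `O=[N+]([O-])c1ccc(COc2cccc(Nc3ncnc4cc5c(cc34)OCCOCCOCCOCCO5)c2)cc1` differs from compound 3 by nitro in place of trifluoromethyl on an aromatic carbon. Among the measured compounds shown here, no measured step between compounds is available to size this change. In this assay no step beyond the scatter is expected, so the step of a 1.1-fold higher number from compound 3 to compound 4 (0.05 log units; within the scatter) is estimated as small. Compound 4 is expected to give about 30000 nM, between 10000 nM and 100000 nM.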

Compound 4, half-maximal inhibitory concentration: 13800 nM
Compound 4: the middle estimate sits 2.2-fold (0.34 log units) above what was measured, and the stated range covers the measured number.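

Among these compounds, this is the first measured step: in this assay, nitro in place of trifluoromethyl gives a 1.9-fold lower number from compound 3 to compound 4 (0.29 log units; within the scatter). On this aromatic carbon, para to a large group, the exchange brings in 2 hydrogen-bond acceptors without a step beyond the scatter. Compound 4 is a second member with a measured number rather than a limit: the limit of > 100000 nM in this assay, at which 2 of the 4 values shown sit.

Open, going by these compounds, is whether an amine or a carboxylic acid at this position would give a step beyond the scatter. Also open, on these data alone, is whether the same exchange reads alike on the shared core of compound 1.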